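This account rests on a few compounds, and the source may have more. Where it says the series, first, only, none or still open, it means among the compounds named here.

Compound 2, `COC(=O)c1cccc(NC(=O)Nc2cc(C)nc3ccccc23)c1`, stands at the higher of the two numbers in an ADME assay on HEK293 cells (Homo sapiens) for cytotoxicity, with a stated time of 72 h (on this read-out lower numbers stand for an effect already at smaller amounts and higher numbers for an effect only at larger amounts of compound), where compound 2 gives 26000 nM. Its nearest neighbour, compound 1, `COC(=O)c1ccc(NC(=O)Nc2cc(C)nc3ccccc23)cc1`, gives 15000 nM in this assay, and the two lie within the usual scatter of each other. For compound 3, `COc1ccc(NC(=O)Nc2cc(C)nc3ccccc23)cc1OC`, this assay reports only a limit, > 25000 nM. That limit is noted as the limit of > 25000 nM in this assay, at which 1 of the 3 values shown sits.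

Compound 4, `Cc1cc(NC(=O)Nc2cccc(C(C)(C)C)c2)c2ccccc2n1`, has not yet been measured in this assay. It differs from compound 2 in one place: tert-butyl in place of methoxycarbonyl on an aromatic carbon.

For the measured compounds named here, no measured step of this kind is available. The expected step from compound 2 to compound 4 in this assay is a 1.3-fold lower number from compound 2 to compound 4 (0.11 log units; within the scatter), which is not beyond the scatter in either direction. Compound 4 is therefore estimated at 20000 nM, with a range from 8000 nM to 50000 nM.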

Compound 4, half-maximal effective concentration: > 25000 nM
Compound 4: no number, only a limit; the forecaster's own chance of this, stated with the estimate: 35%; middle value at least 1.2-fold (0.09 log units) from the limit.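

In this assay, for the compounds shown here, compound 4 gives only a limit (> 25000 nM), so no step from compound 2 to compound 4 can be read. The compounds shown leave open whether tert-butyl in place of methoxycarbonyl on an aromatic carbon shifts the number at all.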